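Allyl to Phenyl on a Triazole Nitrogen: Paw Edema

A few compounds are considered here, and "the series" means these few. Any claim that something is new, unique, unknown or untested is made for them only; others in the source may bear on it.

Measured compounds:
- compound 1, `C=CCn1c(SCC(=O)Nc2ccc(/C(C)=N/O)cc2)nnc1-c1ccccc1`: 73%
- compound 2, `C/C(=N\O)c1ccc(NC(=O)CSc2nnc(-c3ccccc3)n2-c2ccccc2)cc1`: 63%
- compound 3, `C=CCn1c(SCC(=O)Nc2ccc(C(C)=O)cc2)nnc1-c1ccc(OC)cc1`: 52%

Of the compounds shown here, three have been tested in a functional assay on the whole organism (strain albino) for inhibition, with Rattus norvegicus as the target, read by paw edema, with stated times of 30 min and 3 h, at a dose of 0.28 mmol/kg by the oral route; on this read-out lower numbers stand for less inhibition and higher numbers for more inhibition at the one dose given (going by the name of the read-out). Compound 1 `C=CCn1c(SCC(=O)Nc2ccc(/C(C)=N/O)cc2)nnc1-c1ccccc1` gives 73% in this assay. Compound 2 `C/C(=N\O)c1ccc(NC(=O)CSc2nnc(-c3ccccc3)n2-c2ccccc2)cc1` differs from compound 1 by one change, (phenyl in place of allyl on an aromatic nitrogen), and in this assay compound 2 gives 63%; the step of a number 10 percentage points lower from compound 1 to compound 2 (within the scatter) is within the scatter, so the two numbers cannot be told apart with confidence. Compound 3 `C=CCn1c(SCC(=O)Nc2ccc(C(C)=O)cc2)nnc1-c1ccc(OC)cc1` gives 52% in this assay, the lowest of the three numbers; the difference between its core and the core of compound 1 is not broken down here.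

Compound 4 `COc1ccc(-c2nnc(SCC(=O)Nc3ccc(C(C)=O)cc3)n2-c2ccccc2)cc1` has not yet been measured. It differs from compound 3 by phenyl in place of allyl on an aromatic nitrogen. This is the same kind of change as that from compound 1 to compound 2, but the place is not identical: in compound 3 the nitrogen lies next to the ring atom that bears a 4-methoxyphenyl group, whereas in compound 1 that ring atom bears a phenyl group. Among the compounds with values here, because the single precedent, a number 10 percentage points lower from compound 1 to compound 2 (within the scatter), was small and within the scatter, the step from compound 3 to compound 4 is expected to be of similar size, a number 9 percentage points lower from compound 3 to compound 4 (within the scatter), though one pair is a thin basis. Compound 4 is therefore estimated to give 43% in this assay, with a plausible range from 28% to 57%.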

Compound 4, a percentage reported as inhibition, in the whole organism at one dose (the size of the read-out at that dose, not a potency): 58%
The estimate for compound 4 lay 15 percentage points below the measured number; measured number above the stated range.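

In this assay, putting phenyl in place of allyl on the aromatic nitrogen gives a number 6 percentage points higher from compound 3 to compound 4 (within the scatter), so on this core the step taken alone cannot be told apart from the ordinary noise of repeated measurements. Set beside the earlier step, however, the same change does not behave as one fixed shift that can simply be carried from one core to another: the same change on two cores in this assay, a number 10 percentage points lower (within the scatter) from compound 1 to compound 2 and a number 6 percentage points higher (within the scatter) from compound 3 to compound 4, 16 percentage points apart, beyond the scatter of two such steps This rests on only two pairs of compounds, and the core of compound 1 and the core of compound 3 differ in more than one place, with an oxime against a ketone and a phenyl against a 4-methoxyphenyl group, so it does not show which of these differences matters or what the change would do on a third core.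

The compounds shown carry only allyl or phenyl on that nitrogen, which leaves open how a saturated chain such as propyl, or a chain ending in an amine, would read out. Also open, on these data alone, is how the oxime and the ketone compare with the 4-methoxyphenyl group held fixed, a comparison that would separate the two core differences.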